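Removing the methylsulfonyl group from the low-activity pair

The source may report more compounds than this note shows. Statements on the series, on what has been measured and on what is new or still open speak of the compounds shown alone.

Measured compounds:
compound 1, `CS(=O)(=O)c1ccc(-c2cnc3[nH]cc(-c4nnc(-c5ccccc5)o4)c(=O)c3c2)cc1`, 8.6% in a functional assay on HCT-116 cells (Homo sapiens) for inhibition, read by MTT assay, with a stated time of 24 h, tested at 5 uM; on this read-out lower numbers stand for less inhibition of growth and higher numbers for more inhibition of growth at the one concentration tested
compound 2, `CS(=O)(=O)c1ccc(-c2cnc3[nH]cc(-c4nnc(-c5ccc(Cl)cc5)o4)c(=O)c3c2)cc1`, 16.4% in this assay

Within the data shown here, compound 2 stands highest of the two numbers in this assay, but its only neighbour is compound 1, and the step of a number 7.8 percentage points higher from compound 1 to compound 2 (within the scatter) lies within the scatter, so the two values show no difference that can be trusted; both sit in the low range of the read-out.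

Compound 3, `O=c1c(-c2nnc(-c3ccc(Cl)cc3)o2)c[nH]c2ncc(-c3ccccc3)cc12`, has not been measured. It differs from compound 2 in one place: hydrogen in place of methylsulfonyl on an aromatic carbon. Among the measured compounds shown here, no measured step touches this change; the single measured step, the addition of chloro from compound 1 to compound 2, concerns a different position and was within the scatter. The data therefore give no direction for the loss of the methylsulfonyl group, and the estimate can only rest on the low level shared by compound 1 and compound 2. Compound 3 is expected to give 12%, within a range from 0% to 32%. This estimate means a step of a number 4.4 percentage points lower from compound 2 to compound 3 (within the scatter), that is, no change expected beyond the scatter.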

Compound 3, percent growth inhibition at one concentration: 12.3%
Compound 3: the middle estimate sits 0.3 percentage points below what was measured; the range from low to high includes it.
By their numbers in this assay, from the lowest: compounds 1, 3 and 2 (each within the scatter of the next).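

In this assay, among these compounds, the change from 4-(methylsulfonyl)phenyl to phenyl gives a number 4.1 percentage points lower from compound 2 to compound 3 (within the scatter), which is the first reading of this position, on an aromatic carbon para to a large group. The earlier step concerned chloro on the other aryl group and said nothing about this carbon; now the methylsulfonyl group, with its two hydrogen-bond acceptors and four heavy atoms, can be replaced by hydrogen without a difference the read-out can separate from scatter, at least in the chloro-bearing series. No measurement is available that would explain this lack of separation, or tell what the group does or does not contribute at this carbon.

The compounds shown leave open whether any group at this carbon can lift the read-out out of the low range that all three share, for instance an amine or a carboxylic acid in place of the hydrogen. They also leave open whether the same replacement reads alike when the other phenyl ring carries hydrogen instead of chloro, since this change has been read in one setting only.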